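The source may hold more compounds than are shown below. What is called first, only, known or untested is meant among the compounds shown, and "the series" means these compounds.

Compounds measured so far:
compound 1, `O=C(/C=C\Nc1ccc(Cl)cc1)c1cn(-c2ccccc2)nc1-c1ccccc1`: 14100 nM
compound 2, `O=C(/C=C\Nc1ccc(Cl)cc1)c1cn(-c2ccccc2)nc1-c1ccc(F)cc1`: 6700 nM
compound 3, `COc1ccc(-c2nn(-c3ccccc3)cc2C(=O)/C=C\Nc2ccc(Cl)cc2)cc1`: 2970 nM

In a functional assay on A549 cells (Homo sapiens) for antiproliferative activity, read by MTT assay, with a stated time of 48 h (a lower number here means a stronger inhibitor, a higher number a weaker inhibitor), compound 3 gives the lowest number of the three, with compound 2 nearest and compound 1 furthest from it. The steps seen so far all concern the aryl group on the shared core: a 2.1-fold lower number from compound 1 to compound 2 (0.32 log units; beyond the scatter), a 4.7-fold lower number from compound 1 to compound 3 (0.68 log units; beyond the scatter) and a 2.3-fold lower number from compound 2 to compound 3 (0.35 log units; beyond the scatter), each modest but beyond the scatter.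

Compound 4, `COc1ccc(-c2nn(-c3ccccc3)cc2C(=O)/C=C\Nc2cc(OC)c(OC)c(OC)c2)cc1`, differs from compound 3 elsewhere: 3,4,5-trimethoxyphenyl in place of 4-chlorophenyl on an amine nitrogen. Within the data shown here, none of the three measured steps touches that part of the molecule, so there is no direct precedent for this change, and the expectation rests on the three values alone, which all lie within a narrow band. Compound 4 is therefore expected to give a number close to that of compound 3, with wide uncertainty in either direction. The estimated step is a 1.2-fold lower number from compound 3 to compound 4 (0.07 log units; within the scatter), and compound 4 is estimated at 2500 nM, in the range 400 nM to 15000 nM.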

Compound 4, half-maximal inhibitory concentration: 11200 nM
Beside the measured number, compound 4's estimate is 4.5-fold (0.65 log units) below it; measured number inside the range.
By their numbers in this assay, from the lowest: compound 3; then compounds 2, 4 and 1 (each within the scatter of the next, the first and the last beyond it).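

In this assay, the aryl group on the amine nitrogen turns out to be a position that responds to change: 3,4,5-trimethoxyphenyl in place of 4-chlorophenyl gives a 3.8-fold higher number from compound 3 to compound 4 (0.58 log units; beyond the scatter). Methoxy on the aryl group of the shared core had gone the other way, with a 4.7-fold lower number from compound 1 to compound 3 (0.68 log units; beyond the scatter), so adding methoxy groups does not lower the number at both places, and compound 4 is the case against any such rule. No measurement at hand explains the rise.

Among these compounds, the single swap removes the chlorine and brings in three methoxy groups at once, so the share of each stays open. A plain phenyl, a 4-methoxyphenyl or a 4-bromophenyl on the amine nitrogen would help separate them.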